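Replacing hydroxy with an amino side chain

The source may report more compounds than this note shows. Statements on the series, on what has been measured and on what is new or still open speak of the compounds shown alone.

Measured so far (a functional assay on HeLa cells (Homo sapiens) for antiproliferative activity, read by CCK-8 assay, with a stated time of 48 h; on this read-out higher numbers stand for weaker inhibition and lower numbers for stronger inhibition):
- Compound 1 `COc1ccc(/C=C\c2cc(OC)c(OC)c(OC)c2)cc1OCc1ccc(CNC(C)(C)C(=O)O)cc1`: > 10000 nM (a limit)
- Compound 2 `COc1ccc(/C=C\c2cc(OC)c(OC)c(OC)c2)cc1OCc1ccc(CN[C@H](C(=O)O)[C@H](C)O)cc1`: > 10000 nM (a limit)
- Compound 3 `COc1ccc(/C=C\c2cc(OC)c(OC)c(OC)c2)cc1OCc1ccc(CO)cc1`: 7600 nM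

Not yet measured: compound 4 `COc1ccc(/C=C\c2cc(OC)c(OC)c(OC)c2)cc1OCc1ccc(CNCCNC(C)=O)cc1`.

Going by the values given here, compound 3 is the only compound here with a number; the other two sit at a limit (the limit of > 10000 nM in this assay, at which 2 of the 3 values shown sit). The next change puts (2-acetamidoethyl)amino in place of hydroxy on a saturated chain carbon bound to an aromatic carbon. Among the compounds with values here, two measured steps bear on this, both running from a substituted amino group to hydroxy (an at least 1.3-fold lower number from compound 1 to compound 3 (0.11 log units; that floor lies within the scatter); an at least 1.3-fold lower number from compound 2 to compound 3 (0.11 log units; that floor lies within the scatter)). Each is only a floor lying within the scatter, so neither sets a direction. In this assay the expected step is therefore none beyond the scatter (a 1.1-fold higher number from compound 3 to compound 4 (0.02 log units; within the scatter)). Compound 4 is estimated at 8000 nM (expected range 2500 nM to 20000 nM).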

Compound 4, half-maximal inhibitory concentration: 6400 nM
Estimate against measurement, compound 4: 1.3-fold (0.10 log units) above; low and high end bracket the measured number.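

In this assay, (2-acetamidoethyl)amino is the only amino side chain here with a number, and no difference from hydroxy can be read at this place: a 1.2-fold lower number from compound 3 to compound 4 (0.07 log units; within the scatter). Against the two amino acid side chains only floors can be read, an at least 1.5-fold lower number from compound 2 to compound 4 (0.19 log units; that floor lies within the scatter) and an at least 1.5-fold lower number from compound 1 to compound 4 (0.19 log units; that floor lies within the scatter), so neither sets a direction. Both floors rest on a limit rather than a number: the limit of > 10000 nM in this assay, at which 2 of the 4 values shown sit.

On these data alone, it remains open whether a primary amine or a longer chain on this carbon would move the number beyond the scatter from compound 3.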